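The compounds below may be only part of what the source reports. "The series", "measured", "known", "first", "only" and "open" are said of these compounds alone.

Measured in a functional assay on A549 cells (Homo sapiens) for inhibition, read by MTT assay, with a stated time of 72 h; a lower number here means a stronger inhibitor of growth, a higher number a weaker inhibitor of growth:
- compound 1 `CCOC(=O)/C=C/C1=CC[C@H]2C(C)(C)CCC[C@]2(C)[C@H]1C=O` gives 25000 nM
- compound 2 `CC(=O)/C=C/C1=CC[C@H]2C(C)(C)CCC[C@]2(C)[C@H]1C=O` gives 24000 nM

For the measured compounds named here, compound 2 cannot be separated from compound 1, the only other measured compound, as their values lie within the scatter. Compound 3 `C#CCCCOC(=O)/C=C/C1=CC[C@H]2C(C)(C)CCC[C@]2(C)[C@H]1C=O` differs from compound 2 by (pent-4-yn-1-yl)oxy in place of methyl on a carbonyl carbon, with (pent-4-yn-1-yl)oxy in place of methyl on a carbonyl carbon. Going by the values given here, the one measured step at this carbonyl carbon, a 1.0-fold lower number from compound 1 to compound 2 (0.02 log units; within the scatter), lies within the scatter. Among the compounds with values here, no measured compound carries a triple bond, so the expectation rests on that single step, and no change beyond the scatter is expected in this assay. The estimated step is a 1.1-fold lower number from compound 2 to compound 3 (0.04 log units; within the scatter) here. Compound 3 is expected at 22000 nM, with an estimated range of 10000 nM to 50000 nM overall.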

Compound 3, concentration for 50% growth inhibition: 30000 nM
Compound 3: the middle estimate sits 1.4-fold (0.13 log units) below what was measured; the measured number falls inside the stated range.
By their numbers in this assay, from the lowest: compounds 2, 1 and 3 (each within the scatter of the next).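

In this assay, (pent-4-yn-1-yl)oxy in place of methyl on the carbonyl carbon gives (a 1.3-fold higher number from compound 2 to compound 3 (0.10 log units; within the scatter)), so this position now takes a triple-bond-bearing group as well as methyl and ethoxy with all values within the scatter. Propargyl in place of hydrogen on the saturated chain carbon, two bonds along the chain from an oxygen next to a carbonyl group, gives (a 1.2-fold higher number from compound 1 to compound 3 (0.08 log units; within the scatter)). No supporting data explain why these values stay together. Open, from the compounds shown here alone, is whether an amine or a carboxylic acid at this carbonyl carbon would give a step beyond the scatter.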